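A few compounds are considered here, and "the series" means these few. Any claim that something is new, unique, unknown or untested is made for them only; others in the source may bear on it.

Compound 1, `COc1ccc(-c2cc3[nH]nc(-c4cc(OC)c(OC)c(OC)c4)n3n2)cc1N`, gives 13800 nM in a functional assay on SGC-7901 cells (Homo sapiens) for antiproliferative activity, read by MTT assay, with a stated time of 72 h; a lower number here means a stronger inhibitor, a higher number a weaker inhibitor.
Compound 2, `COc1ccc(-c2nn3c(-c4ccc(OC)c(OC)c4)nnc3s2)cc1N`, gives 83 nM.
Compound 3, `COc1cccc(-c2nnc3sc(-c4ccc(OC)c(N)c4)nn23)c1`, gives 59 nM.

Compound 3 has the lowest number of the three measured compounds. Going by the values given here, its nearest neighbour is compound 2, and the single step between them, a 1.4-fold lower number from compound 2 to compound 3 (0.15 log units; within the scatter), lies within the scatter, so these two cannot be told apart. Compound 1, which rests on a different core, stands far away with a much higher number, a gap beyond the scatter.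

Compound 4, `COc1ccc(-c2nnc3sc(-c4ccc(OC)c(N)c4)nn23)cc1`, has not yet been measured. It differs from compound 3 in one place: 4-methoxyphenyl in place of 3-methoxyphenyl on an aromatic carbon. Among the compounds with values here, no measured step moves a methoxy group from one ring position to another, so there is no direct precedent. Within the data shown here, the only step that touches the same ring is a 1.4-fold lower number from compound 2 to compound 3 (0.15 log units; within the scatter), in which one methoxy group was removed without a change beyond the scatter. Compound 2 carries both methoxy groups, compound 3 one of them, and compound 4 the other one, so a similar outcome seems likely. For compound 4 the estimated step is a 1.2-fold higher number from compound 3 to compound 4 (0.07 log units; within the scatter), which stays within the scatter. Compound 4 is therefore expected to give about 70 nM in this assay, with a likely range from 25 nM to 200 nM.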

Compound 4, half-maximal inhibitory concentration: 14200 nM
Beside the measured number, compound 4's estimate is 200-fold (2.31 log units) below it; measured number above the stated range.
By their numbers in this assay, from the lowest: compounds 3 and 2 (each within the scatter of the next); then compounds 1 and 4 (each within the scatter of the next).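

Moving one methoxy group around the ring changes the result sharply in this assay: on this aromatic carbon of the five-membered ring with 3 nitrogen, 4-methoxyphenyl in place of 3-methoxyphenyl gives a 240-fold higher number from compound 3 to compound 4 (2.38 log units; beyond the scatter), even though the two compounds have the same atoms. The earlier step made removing a methoxy group from compound 2 look harmless, at a 1.4-fold lower number from compound 2 to compound 3 (0.15 log units; within the scatter), but removing the other methoxy group gives a 170-fold higher number from compound 2 to compound 4 (2.23 log units; beyond the scatter), so it matters which of the two is lost; among these three compounds, the two that keep the methoxy group of compound 3 have low numbers, and compound 4, which lacks it, does not. Nothing available here explains this gap.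

A plain phenyl group with no methoxy at all would help show whether the methoxy group of compound 3 is needed or whether a lone methoxy group in the position found in compound 4 is what raises the number. On these data alone, it also remains open whether an ethoxy group, a hydroxyl group or a chlorine atom could stand in for the methoxy group of the 3-methoxyphenyl ring and keep the number low.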